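Amino in place of hydroxy on the shared core

The source may report more compounds than this note shows. Statements on the series, on what has been measured and on what is new or still open speak of the compounds shown alone.

Measured so far in a functional assay on Vero cells (Chlorocebus sabaeus) for inhibition; on this read-out higher numbers stand for weaker inhibition and lower numbers for stronger inhibition:
Compound 1 `OC[C@H]1O[C@H](n2cnc3c(O)ncnc32)CS1` gives > 100000 nM.
Compound 2 `Nc1nc(O)c2ncn([C@@H]3CS[C@@H](CO)O3)c2n1` gives 63600 nM.
Compound 3 `OC[C@H]1O[C@@H](n2cnc3c(O)ncnc32)CS1` gives > 100000 nM.

For compound 1 this assay reports only a limit, not a number. The same holds for compound 3, which shares every atom and bond with compound 1 and differs only in configuration as drawn; the step that the two limits leave unreadable from compound 1 to compound 3 therefore cannot be read, because the limit of > 100000 nM in this assay, at which 2 of the 3 values shown sit, hides it. Going by the values given here, compound 2 carries an amino group where compound 1 has a hydrogen, and the step of an at least 1.5-fold lower number from compound 1 to compound 2 (0.19 log units; that floor lies within the scatter) is the only measured change in this assay that gives a readable size at all, and even its floor lies within the scatter.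

Compound 4 `Nc1ncnc2c1ncn2[C@@H]1CS[C@@H](CO)O1` differs from compound 1 by amino in place of hydroxy on an aromatic carbon. Among the compounds with values here, no measured pair shows this exact exchange, and the one readable step ends inside the scatter, so the expectation for compound 4 stays close to where compound 1 stands. The estimated step is a step that the limit leaves unreadable from compound 1 to compound 4, and compound 4 is expected to give about 120000 nM, within 30000 nM to 500000 nM.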

Compound 4, half-maximal inhibitory concentration: > 100000 nM
Compound 4: a limit, no number (the forecaster's own chance of this, stated with the estimate: 55%); the middle value does not contradict the limit.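

In this assay, going by these compounds alone, compound 4 gives > 100000 nM, a limit and not a number, so no step from compound 1 to compound 4 can be read: the limit of > 100000 nM in this assay, at which 3 of the 4 values shown sit. The compounds shown leave open whether amino in place of hydroxy on an aromatic carbon changes inhibition at all.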